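Lengthening a sulfonamide chain in a cytotoxicity test

This account rests on a few compounds, and the source may have more. Where it says the series, first, only, none or still open, it means among the compounds named here.

Three compounds have been examined so far in a toxicity assay on C8166 cells (Homo sapiens) for cytotoxicity, read by MTT assay, with a stated time of 72 h (on this read-out higher numbers stand for lower toxicity in this test and lower numbers for higher toxicity in this test), with these results:

- compound 1 `O=C(NCc1ccc(F)cc1)c1nc(NCCO)c2cccnc2c1O` (91000 nM)
- compound 2 `C[C@H](Nc1c(C(=O)NCc2ccc(F)cc2)nc(Br)c2cccnc12)c1ccccc1` ("not determined" (no result reported))
- compound 3 `CS(=O)(=O)NCCCN(c1nc(C(=O)NCc2ccc(F)cc2)c(O)c2ncccc12)S(C)(=O)=O` (64000 nM)

Compound 3 gives 64000 nM in this assay and compound 1 gives 91000 nM there, so these two numbers lie within the usual scatter of each other. Compound 2 has no number to set beside them.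

The next compound, compound 4 `CS(=O)(=O)NCCCCCCN(c1nc(C(=O)NCc2ccc(F)cc2)c(O)c2ncccc12)S(C)(=O)=O`, awaits measurement. It differs from compound 3 in one place: 3-(methanesulfonamido)propyl in place of methanesulfonamido on a saturated chain carbon, three bonds along the chain from a sulfonamide nitrogen and the same difference can be read as 3-(methanesulfonamido)propyl to 6-(methanesulfonamido)hexyl. Among the compounds with values here, no measured pair differing in one place is available to size such a change. Within the data shown here, the only guide is compound 3 at 64000 nM and compound 1 at 91000 nM which carry different groups on the shared core and still sit within the scatter of each other. The estimated step of a 1.3-fold lower number from compound 3 to compound 4 (0.11 log units; within the scatter) is therefore expected to stay within the scatter, leaning slightly towards a lower number. For compound 4 the expected value is 50000 nM with an estimated range from 20000 nM to 110000 nM in this test.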

Compound 4, half-maximal cytotoxic concentration: 37000 nM
The estimate for compound 4 lay 1.4-fold (0.13 log units) above the measured number; measured number inside the range.
By their numbers in this assay, from the lowest: compounds 4, 3 and 1 (each within the scatter of the next, the first and the last beyond it).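

Putting 3-(methanesulfonamido)propyl in place of methanesulfonamido on a saturated chain carbon, three bonds along the chain from a sulfonamide nitrogen, gives a 1.7-fold lower number from compound 3 to compound 4 (0.24 log units; within the scatter) in this assay. Within the data shown here, this is the first pair that differs in one place, and it gives a first size for a change at this position: the same difference, read as 3-(methanesulfonamido)propyl to 6-(methanesulfonamido)hexyl, keeps the terminal methanesulfonamido group and the counted hydrogen-bond donors and acceptors, and the two numbers stay within the usual scatter of each other. No measurement at hand offers an explanation for this step, so the result stands only as a size.

A single step cannot show whether the chain has any real trend in this test, or whether a still longer chain would carry the number beyond the scatter. It also leaves open what would happen with an amine or a carboxylic acid in place of the methanesulfonamido group at the chain end, or with a shorter chain such as 2-(methanesulfonamido)ethyl on the same core.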